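Adding an Iodo Group to Compound 3: Expected Outcome

A few compounds are considered here, and "the series" means these few. Any claim that something is new, unique, unknown or untested is made for them only; others in the source may bear on it.

Compound 1, `COc1ccc2nc(NC(c3cn(-c4ccccc4)nc3-c3cccc(I)c3)c3c(O)ccc4ccccc34)sc2c1`, gives 39300 nM in a functional assay on A549 cells (Homo sapiens) for antiproliferative activity, read by MTT assay, with a stated time of 48 h; on this read-out lower numbers stand for stronger inhibition and higher numbers for weaker inhibition.
Compound 2, `COc1ccc2nc(NC(c3cn(-c4ccccc4)nc3-c3ccccc3)c3c(O)ccc4ccccc34)sc2c1`, gives 44600 nM.
Compound 3, `Oc1ccc2ccccc2c1C(Nc1nc2ccc(Cl)cc2s1)c1cn(-c2ccccc2)nc1-c1ccccc1`, gives 51100 nM.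

The three numbers lie within the usual scatter of one another, so no order among them can be read. Compound 4, `Oc1ccc2ccccc2c1C(Nc1nc2ccc(Cl)cc2s1)c1cn(-c2ccccc2)nc1-c1ccc(I)cc1`, is not yet measured; it differs from compound 3 by iodo in place of hydrogen on an aromatic carbon. The same kind of change was made once before, as iodo in place of hydrogen on an aromatic carbon, and gave a 1.1-fold lower number from compound 2 to compound 1 (0.05 log units; within the scatter). The two places are not identical: in compound 1 the iodo sits meta to a large group, in compound 4 para to a large group. The cores of compound 2 and compound 3 differ by chloro in place of methoxy on an aromatic carbon. Because a 1.1-fold lower number from compound 2 to compound 1 (0.05 log units; within the scatter) stayed within the scatter, compound 4 is expected to show a 1.1-fold lower number from compound 3 to compound 4 (0.04 log units; within the scatter) in this assay. The estimate for compound 4 is 47000 nM, expected between 25000 nM and 95000 nM.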

Compound 4, half-maximal inhibitory concentration: 29000 nM
Compound 4: the middle estimate sits 1.6-fold (0.21 log units) above what was measured; low and high end bracket the measured number.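

In this assay, iodo in place of hydrogen gives a 1.8-fold lower number from compound 3 to compound 4 (0.25 log units; within the scatter), a step that stays within the usual scatter. Set beside the earlier case, the two steps cannot be told apart: the same change on two cores in this assay, a 1.1-fold lower number (0.05 log units; within the scatter) from compound 2 to compound 1 and a 1.8-fold lower number (0.25 log units; within the scatter) from compound 3 to compound 4, 1.6-fold (0.19 log units) apart, within the scatter of two such steps

So these two pairs give no sign that the core alters what this change does. They do not show that the change has a real effect on either core, as neither step goes beyond the scatter, and the iodo does not sit at the same place in the two pairs.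

The compounds shown leave open whether an amine or a carboxylic acid in place of the iodo would give a clearer step. They also leave open how the same iodo change would behave on a third core.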